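The compounds below may be only part of what the source reports. "The series", "measured", "known", "first", "only" and "open" are said of these compounds alone.

Three compounds have been measured so far in a functional assay on RPMI-8226 cells (Homo sapiens) for inhibition, read by sulforhodamine B assay, with a stated time of 48 h, tested at 10 uM; on this read-out higher numbers stand for more inhibition at the one concentration tested (going by the name of the read-out) and lower numbers for less inhibition:

compound 1, `c1ccc(-c2cn3ccnc3c(-c3ccc4ncn(C5CCCCC5)c4c3)n2)cc1`: compound 1 gives 85.7%
compound 2, `COc1ccc(-c2cn3ccnc3c(-c3ccc4ncn(C5CCCCC5)c4c3)n2)cc1`: compound 2 gives 95.6%
compound 3, `c1cn2cc(-c3ccsc3)nc(-c3ccc4ncn(C5CCCCC5)c4c3)c2n1`: compound 3 gives 37.9%

On these numbers compound 3 stands lowest of the three. Its nearest neighbour is compound 1, and the gap a number 47.8 percentage points lower from compound 1 to compound 3 (beyond the scatter) lies beyond the scatter; the gap to compound 2, a number 57.7 percentage points lower from compound 2 to compound 3 (beyond the scatter), is larger still. Between the two phenyl-bearing compounds the step of a number 9.9 percentage points higher from compound 1 to compound 2 (within the scatter) stays within the scatter.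

The next compound, compound 4, is `Clc1ccc(-c2cn3ccnc3c(-c3ccc4ncn(C5CCCCC5)c4c3)n2)cc1`. Its change from compound 3 is 4-chlorophenyl in place of thiophen-3-yl on an aromatic carbon.

Two of the measured steps bear on this change directly: both a number 47.8 percentage points lower from compound 1 to compound 3 (beyond the scatter) and a number 57.7 percentage points lower from compound 2 to compound 3 (beyond the scatter) show that going from a phenyl or 4-methoxyphenyl group to thiophen-3-yl lowered the read-out sharply. Compound 4 reverses that direction, bringing a six-membered aromatic ring of carbon only back in, and the step of a number 9.9 percentage points higher from compound 1 to compound 2 (within the scatter) suggests that what sits on such a ring matters little here. A large upward step is therefore expected in this assay, of the order of a number 48.1 percentage points higher from compound 3 to compound 4 (beyond the scatter). Compound 4 is estimated at 86%, with a range of 66% to 97%.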

Compound 4, a percentage reported as inhibition, at one concentration (the size of the read-out at that concentration, not a potency): 19%
Beside the measured number, compound 4's estimate is 67 percentage points above it; measured number outside the range, below it.
By their numbers in this assay, from the lowest: compound 4; then compound 3; then compounds 1 and 2 (each within the scatter of the next).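

In this assay, for the compounds shown here, the group at this position turns out to be far less forgiving than the earlier compounds suggested: chloro in place of hydrogen on the six-membered ring gives a number 66.7 percentage points lower from compound 1 to compound 4 (beyond the scatter) and chloro in place of methoxy gives a number 76.6 percentage points lower from compound 2 to compound 4 (beyond the scatter), whereas methoxy in place of hydrogen gave only a number 9.9 percentage points higher from compound 1 to compound 2 (within the scatter) and stayed within the scatter. A six-membered aromatic ring of carbon only is therefore not enough in itself to hold the read-out high, since 4-chlorophenyl in place of thiophen-3-yl gives a number 18.9 percentage points lower from compound 3 to compound 4 (beyond the scatter) and leaves compound 4 the lowest of the series, with thiophen-3-yl no longer marking the low end. Nothing available here explains why the chloro substituent has this effect.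

As far as these compounds go, it remains open whether this drop is particular to chloro or would also appear with fluoro, bromo, trifluoromethyl or an amine in the same place on the ring. The rest of the molecule is the same throughout, so it is also unknown whether the drop would persist with a different group, such as a piperidine, in place of the cyclohexyl group.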